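Removing the hydroxyethyl group from compound 3: expected solubility loss

This account rests on a few compounds, and the source may have more. Where it says the series, first, only, none or still open, it means among the compounds named here.

Compound 3 `CNC(=O)c1cc(C(=O)NC2CC2)cn(Cc2cccc([C@@H](C)O)c2)c1=O` stands highest among the three measured compounds in a physicochemical assay for solubility, read by HPLC, in simulated intestinal fluid, with a stated time of 16 h, tested at 125 ug/mL (a higher number here means a more soluble compound, a lower number a less soluble compound), at 495 ug/mL. Compound 1 `CNC(=O)c1cc(C(=O)NC2CCC2)cn(Cc2ccncc2)c1=O` gives 121 ug/mL in this assay, and compound 2 `CNC(=O)c1cc(C(=O)NC2CCC2)cn(Cc2ccccc2)c1=O` gives 24 ug/mL. Compound 4 `CNC(=O)c1cc(C(=O)NC2CC2)cn(Cc2ccc(C)cc2)c1=O` differs from compound 3 by 4-methylphenyl in place of 3-(1-hydroxyethyl)phenyl on a saturated chain carbon bound to an aromatic nitrogen. Going by the values given here, the only measured step that resembles this change is a 5.0-fold lower number from compound 1 to compound 2 (0.70 log units; beyond the scatter), where an aromatic ring lost its nitrogen. Here a hydrogen-bond donor and acceptor are lost as well, so a drop of at least that size in this assay is expected, about a 20-fold lower number from compound 3 to compound 4 (1.30 log units; beyond the scatter). Compound 4 is therefore estimated at 25 ug/mL in this assay, with a likely range from 7 ug/mL to 80 ug/mL.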

Compound 4, solubility: 11 ug/mL
Estimate against measurement, compound 4: 2.3-fold (0.36 log units) above; the range from low to high includes it.
By their numbers in this assay, from the lowest: compound 4; then compound 2; then compound 1; then compound 3.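

At the saturated chain carbon bound to an aromatic nitrogen, the group matters greatly in this assay, even when the ring stays carbon only: 4-methylphenyl in place of 3-(1-hydroxyethyl)phenyl gives a 45-fold lower number from compound 3 to compound 4 (1.65 log units; beyond the scatter). The difference therefore lies in what the ring carries, not in the ring atoms, which changed in the earlier step. Nothing available explains the size of this step.

The compounds shown leave open whether the step follows the hydroxyl group itself or where the group sits on the ring. On these data alone, how an amine or a carboxylic acid on that ring would read in this assay also remains open.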